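Cyano in Place of Hydrogen: Cytotoxicity Expected Unchanged

A few compounds are considered here, and "the series" means these few. Any claim that something is new, unique, unknown or untested is made for them only; others in the source may bear on it.

Compound 1 `N#Cc1cccc(Cn2cc(CCO)nn2)c1`: in an ADME assay on cells (Mus musculus) for cytotoxicity, read by MTT assay (on this read-out higher numbers stand for lower toxicity in this test and lower numbers for higher toxicity in this test), compound 1 gives > 100000 nM
Compound 2 `CCc1c(CCO)nnn1Cc1ccccc1`: in this assay compound 2 gives > 100000 nM

Both values shown are limits of the assay, not measured numbers. For compound 1 the reading of > 100000 nM is such a limit. For compound 2 the reading of > 100000 nM is likewise a limit, so nothing more exact than that is known about compound 2. Compound 2 therefore stands at the limit of > 100000 nM in this assay, at which 2 of the 2 values shown sit.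

Compound 3 `CCc1c(CCO)nnn1Cc1cccc(C#N)c1` has not yet been measured. It differs from compound 2 in one place: cyano in place of hydrogen on an aromatic carbon. Among the measured compounds shown here, no pair of measured compounds shows the effect of this change, so there is no measured step to lean on. The expected step of a number no higher from compound 2 to compound 3 (the limit leaves the size open) is none beyond the usual scatter. Compound 3 is therefore estimated at 100000 nM, with a range from 50000 nM to 300000 nM, most likely again reported only as a limit.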

Compound 3, half-maximal cytotoxic concentration: > 100000 nM
Compound 3 was reported as a limit; the forecaster's own chance of this, stated with the estimate: 85%; the middle value lies on the limit itself.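

Among the compounds shown here, no step from compound 1 or compound 2 to compound 3 can be read in this assay, because all three compounds rest on one limit of the assay: the limit of > 100000 nM in this assay, at which 3 of the 3 values shown sit. The compounds shown leave open whether cyano or ethyl changes cytotoxicity at all.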